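Swapping bromo for hydrogen on a weak compound

The compounds below may be only part of what the source reports. "The series", "measured", "known", "first", "only" and "open" are said of these compounds alone.

Compound 1 (`C#CCNC(=O)c1csc(C#C)n1`) carries an ethynyl group, and in a functional assay on NCI-H522 cells (Homo sapiens) for cytotoxicity, with a stated time of 3 days (on this read-out lower numbers stand for stronger inhibition and higher numbers for weaker inhibition), compound 1 gives 2100 nM as its measured value. Compound 2 (`C#CCNC(=O)c1csc(Br)n1`) has bromo in place of ethynyl on an aromatic carbon. As far as these compounds go, for compound 2 the result > 40000 nM is a limit of the assay and not a number, so its true position is unknown. The change to compound 3 (`C#CCNC(=O)c1cscn1`) is hydrogen in place of bromo on an aromatic carbon and the rest of the molecule stays the same.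

Among the compounds with values here, only one measured step bears on this aromatic carbon. It is an at least 19-fold higher number from compound 1 to compound 2 (1.27 log units; beyond the scatter) and it is large, but it concerns the loss of ethynyl. Like compound 2, compound 3 has no ethynyl group, and so far only compound 1 gives a number in this assay among these compounds. No recovery towards compound 1 is therefore expected. The expected step is a number no higher from compound 2 to compound 3 (the limit leaves the size open) and amounts to no change beyond the scatter. For compound 3 the estimated value is 40000 nM with an expected range from 15000 nM to 80000 nM and a good chance of another limit.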

Compound 3, half-maximal inhibitory concentration: > 40000 nM
Compound 3 ended at the assay's limit; the forecaster's own chance of this, stated with the estimate: 75%; the middle value lies on the limit itself.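

In this assay the change from ethynyl to hydrogen on this aromatic carbon gives an at least 19-fold higher number from compound 1 to compound 3 (1.27 log units; beyond the scatter) and so stands beside the earlier change to bromo: with either replacement, the measurable value of compound 1 is gone. Compound 3 gives > 40000 nM as a limit of the assay and not a number, so removing bromo, leaving only hydrogen on this carbon, brings no readable value back. The step between compound 2 and compound 3 cannot be read, and neither bromo nor hydrogen can be placed ahead of the other, because both compounds stop at the same limit: the limit of > 40000 nM in this assay, at which 2 of the 3 values shown sit.

Ethynyl is thus the only group on this carbon with a readable value here, and the full size of its loss stays unknown, since only a lower bound on the step is available. As far as these compounds go, whether a nitrile, a longer alkyne chain such as propynyl, or an amine on this carbon would also give a measurable value stays open.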